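Replacing 5-methylthiophen-2-yl in compound 3

The source may report more compounds than this note shows. Statements on the series, on what has been measured and on what is new or still open speak of the compounds shown alone.

Values measured so far in a functional assay on DU-145 cells (Homo sapiens) for inhibition, read by trypan blue exclusion, with a stated time of 96 h (on this read-out lower numbers stand for stronger inhibition of growth and higher numbers for weaker inhibition of growth), are:
- compound 1 `Cc1ccc(S(=O)(=O)/C(=C/c2ccc(C)s2)C(=O)c2ccc(Br)cc2)cc1` gives 25000 nM
- compound 2 `COc1ccc(S(=O)(=O)/C(=C/c2ccc(C)s2)C(=O)c2ccc(Cl)cc2)cc1` gives 25000 nM
- compound 3 `Cc1ccc(S(=O)(=O)/C(=C/c2ccc(C)s2)C(=O)c2ccc(Cl)cc2)cc1` gives 50000 nM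

Compound 3 lies within the scatter of both other compounds. The two measured steps, a 2.0-fold higher number from compound 1 to compound 3 (0.30 log units; within the scatter) and a 2.0-fold higher number from compound 2 to compound 3 (0.30 log units; within the scatter), both stayed within the scatter and lie at other places in the molecule.

Compound 4 `Cc1ccc(S(=O)(=O)/C(=C/c2cc(C)ccc2C)C(=O)c2ccc(Cl)cc2)cc1` carries 2,5-dimethylphenyl in place of 5-methylthiophen-2-yl on a double-bonded chain carbon bound to a double-bonded chain carbon. Among the compounds with values here, no measured step covers this exchange directly, so only a weak guide exists, and no change beyond the scatter is expected in this assay here. The expected step is a 1.4-fold lower number from compound 3 to compound 4 (0.15 log units; within the scatter) in size. For compound 4 the estimated value is 35000 nM with an expected range from 12000 nM to 100000 nM in this read-out.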

Compound 4, concentration for 50% growth inhibition: 1000 nM
For compound 4 the middle estimate is 35-fold (1.54 log units) above the measured one; measured number below the stated range.
By their numbers in this assay, from the lowest: compound 4; then compounds 1, 2 and 3 (each within the scatter of the next).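

In this assay, putting 2,5-dimethylphenyl in place of 5-methylthiophen-2-yl gives a 50-fold lower number from compound 3 to compound 4 (1.70 log units; beyond the scatter), the only listed step beyond the scatter. This position therefore moves the read-out strongly, unlike the chloro-for-bromo and methyl-for-methoxy exchanges elsewhere in the molecule. No evidence is available to explain this step.

The compounds shown leave open whether the ring itself or its two methyl groups carry the change, which an unsubstituted phenyl or a pyridyl at this place could help separate. As far as these compounds go, whether the bromo and methoxy exchanges behave the same alongside 2,5-dimethylphenyl also remains open.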